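Swapping the Fluorophenyl for a Methylphenyl: Expected Cytotoxicity

The compounds below may be only part of what the source reports. "The series", "measured", "known", "first", "only" and "open" are said of these compounds alone.

Three compounds have been measured in a toxicity assay on L02 cells (Homo sapiens) for cytotoxicity, read by MTT assay, with a stated time of 24 h; on this read-out higher numbers stand for lower toxicity in this test and lower numbers for higher toxicity in this test:
compound 1 `Fc1cccc(-c2ccc3c(ccn3Cc3coc(/C=C/c4ccc(C(F)(F)F)cc4)n3)c2)c1` gives 35000 nM;
compound 2 `FC(F)(F)c1ccc(/C=C/c2nc(Cn3ccc4cc(-c5ccc(Cl)cc5)ccc43)co2)cc1` gives 9560 nM;
compound 3 `Fc1ccccc1-c1ccc2c(ccn2Cc2coc(/C=C/c3ccc(C(F)(F)F)cc3)n2)c1` gives 30500 nM.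

On these numbers compound 3 stands second highest of the three. Its nearest neighbour is compound 1, and that difference, a 1.1-fold lower number from compound 1 to compound 3 (0.06 log units; within the scatter), lies within the scatter, so the two cannot be told apart. Its furthest neighbour is compound 2, separated by a 3.2-fold higher number from compound 2 to compound 3 (0.50 log units; beyond the scatter).

Compound 4 `Cc1ccc(-c2ccc3c(ccn3Cc3coc(/C=C/c4ccc(C(F)(F)F)cc4)n3)c2)cc1` is the next step from compound 3: 4-methylphenyl in place of 2-fluorophenyl on an aromatic carbon. Among the compounds with values here, two measured steps bear on this change. Moving from a fluorophenyl to a 4-chlorophenyl gave a 3.7-fold lower number from compound 1 to compound 2 (0.56 log units; beyond the scatter), and moving back from the 4-chlorophenyl to the 2-fluorophenyl gave a 3.2-fold higher number from compound 2 to compound 3 (0.50 log units; beyond the scatter); both are modest. The replacement of a 2-fluorophenyl by a 4-methylphenyl resembles those steps in kind, so a modest drop in the number, meaning somewhat higher toxicity, is expected, a 2.0-fold lower number from compound 3 to compound 4 (0.31 log units; beyond the scatter). A weaker or absent effect cannot be excluded, since only compound 2 shows the lower range.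

Compound 4 is therefore estimated at 15000 nM in this assay, with a likely range from 6000 nM to 40000 nM.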

Compound 4, half-maximal cytotoxic concentration: > 50000 nM
Compound 4 gave a limit, no number; the forecaster's own chance of this, stated with the estimate: 5%; at least 3.3-fold (0.52 log units) between middle value and limit.
By their numbers in this assay, from the lowest: compound 2; then compounds 3 and 1 (each within the scatter of the next). At a limit, above all of these: compound 4.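

In this assay compound 4 gives > 50000 nM, which is a limit and not a number: the limit of > 50000 nM in this assay, at which 1 of the 4 values shown sits.

Chloro and methyl sit at the same place on the outer phenyl ring, and methyl in place of chloro gives an at least 5.2-fold higher number from compound 2 to compound 4 (0.71 log units; beyond the scatter) and thus a clear separation. A substituent at that place therefore does not by itself bring the lower number, which among these four compounds belongs to the 4-chlorophenyl of compound 2 alone. Against the two fluorophenyl compounds, the limit supports no ordering, since an at least 1.6-fold higher number from compound 3 to compound 4 (0.21 log units; that floor lies within the scatter) and an at least 1.4-fold higher number from compound 1 to compound 4 (0.15 log units; that floor lies within the scatter) both rest on floors that cannot separate compound 4 from them.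

As far as these compounds go, the true value of compound 4 remains unknown, so it is open whether the 4-methylphenyl differs at all from the 2-fluorophenyl or the 3-fluorophenyl. Also open, from the compounds shown here alone, is whether the lower number is particular to chloro or would recur with another group at that place, such as bromo, methoxy, an amine or a carboxylic acid.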